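Aryl for cyclohexyl on the amide of compound 1

The source may report more compounds than this note shows. Statements on the series, on what has been measured and on what is new or still open speak of the compounds shown alone.

Compound 1 `Nc1nccc2cc(CNC(=O)Cn3cnc(C(=O)NC4CCCCC4)n3)ccc12` was tested in an assay for inhibition of histone-lysine N-methyltransferase, H3 lysine-79 specific (Homo sapiens), read by luminescence, with a stated time of 1 h (a higher number here means a weaker inhibitor, a lower number a stronger inhibitor), and gave > 100000 nM, which is a limit of the assay rather than a number. Compound 2 `Nc1ncnc2c1ccn2CCNC(=O)Cn1cnc(C(=O)NC2CCCCC2)n1` likewise reached only a limit in this assay, at > 100000 nM. Going by the values given here, compound 3 `Cc1ccc(NC(=O)c2ncn(CC(=O)NCCn3cnc4[nH]ccc4c3=O)n2)cc1C` is the one member of the set with a number, giving 138000 nM in this assay. Compound 1 therefore stands at the limit of > 100000 nM in this assay, at which 2 of the 3 values shown sit, so no place within the scatter can be assigned to it.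

Compound 4 `CC(C)(C)c1ccc(NC(=O)c2ncn(CC(=O)NCc3ccc4c(N)nccc4c3)n2)cc1` differs from compound 1 in one place: 4-(tert-butyl)phenyl in place of cyclohexyl on an amide-type nitrogen. Among the compounds with values here, no measured step of this kind is available. Compound 3 carries an aryl group on the same amide-type nitrogen and is itself very weak, so the expected step from compound 1 to compound 4 is a step that the limit leaves unreadable from compound 1 to compound 4, which is no change beyond the scatter. On that basis compound 4 is estimated at 150000 nM in this assay, within a range from 50000 nM to 500000 nM, and a limit rather than a number is the more likely report.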

Compound 4, half-maximal inhibitory concentration: 19500 nM
Estimate against measurement, compound 4: 7.7-fold (0.89 log units) above, and the stated range ends above it.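

Setting 4-(tert-butyl)phenyl in place of cyclohexyl on the amide-type nitrogen gives, in this assay, an at least 5.1-fold lower number from compound 1 to compound 4 (0.70 log units; beyond the scatter). With the rest of compound 1 kept, this shows that the group on this nitrogen can move the read-out beyond the scatter. The full size of the step cannot be read, because compound 1 gives only a limit: the limit of > 100000 nM in this assay, at which 2 of the 4 values shown sit.

The compounds shown leave open whether the change comes from the aromatic ring itself or from the tert-butyl group it carries, which a plain phenyl on this nitrogen would separate. They also leave open how far the trend runs on this nitrogen with other groups on the ring, such as a methoxy group or a carboxylic acid.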